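The source may hold more compounds than are shown below. What is called first, only, known or untested is meant among the compounds shown, and "the series" means these compounds.

Measured in an ADME assay on HepG2 cells (Homo sapiens) for cytotoxicity, read by neutral red uptake, with a stated time of 24 h; on this read-out higher numbers stand for weaker inhibition and lower numbers for stronger inhibition:
- compound 1 `CCC(=O)Oc1c(C(C)C)cc2c3c1OC(=O)[C@@]31CCCC(C)(C)[C@@H]1CC2`: 196000 nM
- compound 2 `CCCCC/C=C/C/C=C/CCCCCCCC(=O)Oc1c(C(C)C)cc2c3c1OC(=O)[C@@]31CCCC(C)(C)[C@@H]1CC2`: 289000 nM

For the measured compounds named here, compound 1 stands within the scatter of compound 2, the only other measured compound, so neither separates from the other. Compound 3 `CC(C)c1cc2c3c(c1OC(=O)CCCc1c[nH]c4ccccc14)OC(=O)[C@@]31CCCC(C)(C)[C@@H]1CC2` is unmeasured. Its change from compound 1 is (1H-indol-3-yl)methyl in place of hydrogen on a saturated chain carbon, two bonds along the chain from a carbonyl carbon, with (1H-indol-3-yl)methyl in place of hydrogen on a saturated chain carbon. Going by the values given here, no measured step covers this change. Among the compounds with values here, compound 2, at 289000 nM, gives the only guide, so no step beyond the scatter is expected in this assay. The estimated change is a 1.0-fold higher number from compound 1 to compound 3 (0.01 log units; within the scatter). The expected value for compound 3 is 200000 nM, with a range of 90000 nM to 400000 nM.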

Compound 3, half-maximal inhibitory concentration: 120000 nM
For compound 3 the middle estimate is 1.7-fold (0.22 log units) above the measured one, and the stated range covers the measured number.
By their numbers in this assay, from the lowest: compounds 3, 1 and 2 (each within the scatter of the next, the first and the last beyond it).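

In this assay, (1H-indol-3-yl)methyl in place of hydrogen on a saturated chain carbon, two bonds along the chain from a carbonyl carbon, gives a 1.6-fold lower number from compound 1 to compound 3 (0.21 log units; within the scatter). This position therefore carries the added aromatic group with no step beyond the scatter, which compound 2 could not show without a measured single-place step. No measurement here bears on the reason for this result.

From the compounds shown here alone, whether an amine or a carboxylic acid at the same chain carbon would stay within the scatter remains open. The compounds shown also leave open whether a simple phenyl group there would behave like (1H-indol-3-yl)methyl.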